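The source may report more compounds than this note shows. Statements on the series, on what has been measured and on what is new or still open speak of the compounds shown alone.

Measured compounds:
- Compound 1 `CCn1c(C(=O)N[C@H](C)C(=O)OC)ccc1C(CC)(CC)c1ccc(OCS(=O)(=O)c2ccccc2)c(C)c1` gives > 50000 nM in a functional assay on BXPC-3 cells (Homo sapiens) for antiproliferative activity, read by MTT assay, with a stated time of 24 h (on this read-out lower numbers stand for stronger inhibition and higher numbers for weaker inhibition), a limit of the assay.
- Compound 2 `CCn1c(C(=O)NCCCO)ccc1C(CC)(CC)c1ccc(OCS(=O)(=O)c2ccccc2)c(C)c1` gives 26600 nM in this assay.
- Compound 3 `CCn1c(C(=O)N[C@@H](CO)CCO)ccc1C(CC)(CC)c1ccc(OCS(=O)(=O)c2ccccc2)c(C)c1` gives > 50000 nM in this assay, again a limit of the assay.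

Compound 1 thus sits at the limit, which is where two of the three values shown stand (the limit of > 50000 nM in this assay, at which 2 of the 3 values shown sit). Only compound 2 yields a number, and the steps around it are small: an at least 1.8-fold lower number from compound 1 to compound 2 (0.27 log units; that floor lies within the scatter), while an at least 1.8-fold higher number from compound 2 to compound 3 (0.27 log units; that floor lies within the scatter), both with floors inside the usual scatter.

Compound 4 `CCn1c(C(=O)N[C@@H](C)C(=O)O)ccc1C(CC)(CC)c1ccc(OCS(=O)(=O)c2ccccc2)c(C)c1` differs from compound 1 by 1-carboxyethyl in place of 1-(methoxycarbonyl)ethyl on an amide-type nitrogen. No measured step alters the same part of the amide substituent in this way, so nothing shown speaks directly to the change. Given that compound 1 already rests at the limit and that the other variations on the amide nitrogen moved the read-out little, compound 4 is expected to stay near that limit, with a step that the limit leaves unreadable from compound 1 to compound 4 as the estimated step. Compound 4 is therefore estimated at 60000 nM, within a range from 25000 nM to 150000 nM, most probably reported only as a limit.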

Compound 4, half-maximal inhibitory concentration: 20800 nM
Compound 4: the middle estimate sits 2.9-fold (0.46 log units) above what was measured, outside the stated range (below it).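

In this assay, among the compounds shown here, 1-carboxyethyl in place of 1-(methoxycarbonyl)ethyl on the amide-type nitrogen gives an at least 2.4-fold lower number from compound 1 to compound 4 (0.38 log units; beyond the scatter), a step beyond the scatter, where the floors of the earlier steps stayed inside it. The same holds against 3-hydroxy-1-(hydroxymethyl)propyl, with an at least 2.4-fold lower number from compound 3 to compound 4 (0.38 log units; beyond the scatter). Against 3-hydroxypropyl there is a 1.3-fold lower number from compound 2 to compound 4 (0.11 log units; within the scatter), so compound 2 and compound 4 cannot be told apart, and this position carries two substituents with readable values in this assay.

From the compounds shown here alone, the steps from compound 1 and compound 3 are floors set by limits of the assay, so their full size stays open: the limit of > 50000 nM in this assay, at which 2 of the 4 values shown sit. Also open, going by these compounds, is how an amine, or a longer chain ending in a carboxylic acid, on the amide-type nitrogen would read in this assay.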